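The source may hold more compounds than are shown below. What is called first, only, known or untested is meant among the compounds shown, and "the series" means these compounds.

Measured compounds in an ADME assay on BJ cells (Homo sapiens) for cytotoxicity, read by CellTiter-Glo and resazurin assay, with a stated time of 72 h; on this read-out higher numbers stand for an effect only at larger amounts of compound and lower numbers for an effect already at smaller amounts:
- compound 1 `CC(C)N(Cc1cccc(OCCCCCC(=O)O)c1)C(=O)c1ccc(-c2cccc(OCc3ccccc3)c2)cc1` gives > 26000 nM; this is a limit of the assay, not a number.
- compound 2 `COc1ccc(F)c(-c2ccc(C(=O)N(Cc3cccc(OCCCCCC(=O)O)c3)C(C)C)cc2)c1` gives > 26000 nM; again a limit of the assay.
- compound 3 `CCOC(=O)CCCCCOc1cccc(CN(C(=O)c2ccc(-c3cccnc3)cc2)C(C)C)c1` gives > 26000 nM; also a limit of the assay.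

Where compound 3 stands: no number is available for it in this assay, only a limit, and the other two values shown are limits as well (the limit of > 26000 nM in this assay, at which 3 of the 3 values shown sit). Among the measured compounds shown here, no pair of these three differs in one place only, so no measured step can be drawn from them; all that can be said is that every measured member of the series sits at the same limit.

Compound 4 `CCOC(=O)CCCCCOc1cccc(CN(C(=O)c2ccc(-c3ccc(C(C)=O)s3)cc2)C(C)C)c1` is not yet measured. It differs from compound 3 in one place (5-acetylthiophen-2-yl in place of pyridin-3-yl on an aromatic carbon), that is, 5-acetylthiophen-2-yl in place of pyridin-3-yl on an aromatic carbon.

For the measured compounds named here, with no measured step and all three values at a limit, there is no basis for expecting a step in this assay beyond the scatter in either direction. The step from compound 3 to compound 4 is therefore estimated as a number no higher from compound 3 to compound 4 (the limit leaves the size open). For compound 4 the expected value in this assay is 26000 nM, with a range from 10000 nM to 60000 nM, and most likely the assay will again report only a limit.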

Compound 4, half-maximal effective concentration: > 26000 nM
Compound 4: a limit, no number (the forecaster's own chance of this, stated with the estimate: 75%); the middle value lies on the limit itself.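

In this assay, compound 3 and compound 4 each give only a limit of the assay, not a number, so no step can be read between them: the limit of > 26000 nM in this assay, at which 4 of the 4 values shown sit.

The compounds shown leave open at what concentration any of them would reach a half-maximal effect in this assay, and whether 5-acetylthiophen-2-yl and pyridin-3-yl differ there at all.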